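Aryl sulfonate series: swapping the phenol aryl group

The compounds below may be only part of what the source reports. "The series", "measured", "known", "first", "only" and "open" are said of these compounds alone.

Measured so far:
compound 1 `Cc1ccc(OS(=O)(=O)c2ccc(N3CCN(C)C3=O)cc2)c(C)c1`: 3000 nM
compound 2 `CN1CCN(c2ccc(S(=O)(=O)Oc3cc(Cl)c(Cl)cc3Cl)cc2)C1=O`: 600 nM

Both compounds share the same core and differ only in the aryl group on the sulfonate oxygen. In a functional assay on HT-29 cells (Homo sapiens) for antiproliferative activity, read by sulforhodamine B assay, with a stated time of 48 h (a lower number here means a stronger inhibitor, a higher number a weaker inhibitor), compound 1 gives 3000 nM, the higher of the two numbers, so the weaker inhibitor of the pair. Compound 2 gives 600 nM in this assay, a lower number, and the gap between compound 1 and compound 2 lies beyond the scatter. No other comparison is available.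

Compound 3 `CN1CCN(c2ccc(S(=O)(=O)Oc3ccc(Cl)cc3)cc2)C1=O` is not yet measured. Relative to compound 1 the change is 4-chlorophenyl in place of 2,4-dimethylphenyl on an oxygen. The aryl group of compound 3 carries one chlorine and no methyls; the only measured point with chlorine on that ring, compound 2 with 600 nM, sits well below compound 1. Among the measured compounds shown here, on that basis a moderate move to a lower number is expected, though with only two measured compounds the step may also prove to be within the scatter. The expected step from compound 1 to compound 3 is a 2.0-fold lower number from compound 1 to compound 3 (0.30 log units; within the scatter). Compound 3 is estimated at 1500 nM in this assay, with a range from 500 nM to 5000 nM.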

Compound 3, half-maximal inhibitory concentration: 12000 nM
Compound 3: middle estimate off by 8.0-fold (0.90 log units), on the low side; measured number above the stated range.
By their numbers in this assay, from the lowest: compound 2; then compound 1; then compound 3.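

On the oxygen whose other neighbour is the sulfonyl sulfur, 4-chlorophenyl in place of 2,4-dimethylphenyl gives a 4.0-fold higher number from compound 1 to compound 3 (0.60 log units; beyond the scatter) in this assay, so this position responds to a change of a single aryl group. Compound 2 at 600 nM and compound 3 at 12000 nM both carry chlorine on that ring, so the presence of chlorine alone does not give a low number in this set. Compound 1, with no chlorine, lies between these two chlorinated compounds, and the order therefore does not follow chlorine versus methyl as a simple choice. Nothing available accounts for the size or direction of this step.

The compounds shown leave open whether the higher number of compound 3 goes with the loss of the methyl groups or with the entry of chlorine, as the two change together here. A 4-methylphenyl group on the same oxygen would separate those two changes, and a methoxy group or an amine on that ring would show whether the position accepts anything other than chlorine and methyl.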